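From Nitro to Methoxy on a Shared Core

The compounds below may be only part of what the source reports. "The series", "measured", "known", "first", "only" and "open" are said of these compounds alone.

Of the compounds shown here, three built on one shared core have been tested in a functional assay on the whole organism with Rattus norvegicus as the target, at a dose of 20 mg/kg by the intraperitoneal route; on this read-out higher numbers stand for more inhibition at the one dose given (going by the name of the read-out) and lower numbers for less inhibition. Compound 1 `Nc1nc(N)nc(-c2ccccc2Br)n1` gives 26%. Compound 2 `CCOc1ccccc1-c1nc(N)nc(N)n1` gives -5%, and compound 3 `Nc1nc(N)nc(-c2ccccc2[N+](=O)[O-])n1` gives 11%. Compound 3 thus stands second highest of the three: the step of a number 15 percentage points lower from compound 1 to compound 3 (beyond the scatter) is modest, the step of a number 16 percentage points higher from compound 2 to compound 3 (beyond the scatter) is also modest, so compound 1 sits above it and compound 2 below it.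

Compound 4 `COc1ccccc1-c1nc(N)nc(N)n1` has not yet been measured. It differs from compound 3 in a single place: methoxy in place of nitro on an aromatic carbon.

Going by the values given here, two measured steps bear on this change. The step of a number 16 percentage points higher from compound 2 to compound 3 (beyond the scatter) shows that swapping ethoxy for nitro raised inhibition, so the reverse direction, nitro back to a small oxygen-linked group, should lower it by a comparable amount. The step of a number 31 percentage points lower from compound 1 to compound 2 (beyond the scatter) confirms that the ethoxy compound is the lowest of the three. Methoxy is the nearest relative of ethoxy among the groups seen here, so a modest fall is expected from compound 3 to compound 4, roughly a number 13 percentage points lower from compound 3 to compound 4 (beyond the scatter). Compound 4 is therefore expected to give about -2%, within a range of -20% to 15%.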

Compound 4, a percentage reported as inhibition, in the whole organism at one dose (the size of the read-out at that dose, not a potency) in the Rattus norvegicus assay: 1%
Estimate against measurement, compound 4: 3 percentage points below; the measured number falls inside the stated range.
By their numbers in the Rattus norvegicus assay, from the lowest: compounds 2, 4 and 3 (each within the scatter of the next, the first and the last beyond it); then compound 1.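

In the Rattus norvegicus assay the change from nitro to methoxy at this aromatic carbon gives a number 10 percentage points lower from compound 3 to compound 4 (within the scatter) and the change from ethoxy to methoxy gives a number 6 percentage points higher from compound 2 to compound 4 (within the scatter) at the same place, so compound 4 cannot be told apart from either neighbour, even though the steps printed earlier separate compound 2 from compound 3. Bromo stays apart from this group of compounds, with a number 25 percentage points lower from compound 1 to compound 4 (beyond the scatter) in the same read-out, so at this position the clear difference so far lies between bromo and the other three groups. In a physicochemical assay for lipophilicity (on this read-out lower numbers stand for lower lipophilicity and higher numbers for higher lipophilicity), compound 3 reads 0.49 and compound 4 reads 0.58 on the partition coefficient, and a number 0.09 log units higher from compound 3 to compound 4 (within the scatter) means that this change of group leaves that read-out without a measurable shift.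

On these data alone, whether an amine, a carboxylic acid or a longer chain on the oxygen at this aromatic carbon would stand with bromo or with the other three remains open. Why bromo stands apart also remains open, as nothing given here explains any of these steps.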